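The source may report more compounds than this note shows. Statements on the series, on what has been measured and on what is new or still open speak of the compounds shown alone.

Compounds 1, 2 and 3 share one core, seen in compound 1 `CNS(=O)(=O)c1ccccc1Nc1cc(-c2ccc3ccn(C)c3c2)c2nccnc2c1`, compound 2 `CN(Cc1cncnc1)S(=O)(=O)c1ccccc1Nc1cc(-c2ccc3ccn(C)c3c2)c2nccnc2c1` and compound 3 `Cn1cc(NC(=O)c2ccncc2Nc2cc(-c3ccc4ccn(C)c4c3)c3nccnc3c2)cn1`. In an assay on lysate for inhibition of 6-phosphofructo-2-kinase/fructose-2,6-bisphosphatase 3 (Homo sapiens), with stated times of 0.5 min and 45 min (on this read-out higher numbers stand for weaker inhibition and lower numbers for stronger inhibition), compound 1 gives > 100000 nM, which is a limit of the assay and not a number. In this assay compound 2 likewise gives > 100000 nM, again a limit rather than a number. The step that the two limits leave unreadable from compound 1 to compound 2 therefore cannot be sized. In this assay, for the measured compounds named here, compound 3 gives 26500 nM, the only number among the values shown, while the other two sit at the limit of > 100000 nM in this assay, at which 2 of the 3 values shown sit.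

Compound 4 `CN1CCC(N(C)C(=O)c2ccncc2Nc2cc(-c3ccc4ccn(C)c4c3)c3nccnc3c2)C1` differs from compound 3 at the carbonyl carbon: methyl(1-methylpyrrolidin-3-yl)amino in place of (1-methyl-1H-pyrazol-4-yl)amino on a carbonyl carbon. Going by the values given here, no measured step touches the carbonyl carbon; the single measured step sits on a sulfonamide nitrogen and its size is unreadable. No measured step therefore bears on this change, and no direction can be read from the compounds shown. The step from compound 3 to compound 4 is estimated as a 1.1-fold higher number from compound 3 to compound 4 (0.05 log units; within the scatter), that is, no change beyond the usual scatter, but with a wide range given the absence of any guiding step. Compound 4 is expected to give 30000 nM in this assay, between 7000 nM and 100000 nM.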

Compound 4, half-maximal inhibitory concentration: 39700 nM
The estimate for compound 4 lay 1.3-fold (0.12 log units) below the measured number; low and high end bracket the measured number.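

In this assay the step on the sulfonamide nitrogen cannot be read, so the change on the carbonyl carbon gives the only readable step among these compounds: a 1.5-fold higher number from compound 3 to compound 4 (0.18 log units; within the scatter). Here methyl(1-methylpyrrolidin-3-yl)amino replaces (1-methyl-1H-pyrazol-4-yl)amino, so the five-membered aromatic ring gives way to a five-membered non-aromatic ring and the hydrogen-bond donor of the leaving group is gone, yet the read-out shows no change beyond the usual scatter. Compound 1 and compound 2 still stand at a limit and not at a number, so neither can be set against this pair: the limit of > 100000 nM in this assay, at which 2 of the 4 values shown sit.

For the compounds shown here, compounds 3 and 4 show only that these two groups on the carbonyl carbon cannot be told apart in this assay, and they do not show which part of either group, if any, matters to the read-out. As far as these compounds go, whether a smaller group such as a plain dimethylamino, or a primary amine or a morpholine, on that carbonyl carbon would move the number beyond the scatter remains open.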